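The source may hold more compounds than are shown below. What is called first, only, known or untested is meant among the compounds shown, and "the series" means these compounds.

Of the compounds shown here, three from one series have been tested in a functional assay on the whole organism (strain Swiss albino) for inhibition, with Mus musculus as the target, in the writhing test, with a stated time of 30 min, at a dose of 100 mg/kg; on this read-out lower numbers stand for less inhibition and higher numbers for more inhibition at the one dose given (going by the name of the read-out). Compound 1, `CCN1CCc2c(c(C)nn2C(=O)Nc2ccc(C)cc2C)C1`, gives 56.1% in this assay. Compound 3, `CCN1CCc2c(c(C(C)(C)C)nn2C(=O)Nc2ccc(C)cc2C)C1`, differs from compound 1 only in that (tert-butyl in place of methyl on an aromatic carbon); in this assay compound 3 gives 71.1%, so this change produced a number 15 percentage points higher from compound 1 to compound 3 (beyond the scatter). Compound 2, `CCN1CCc2c(c(C)nn2C(=O)Nc2cccc(C(F)(F)F)c2)C1`, carries a trifluoromethyl group on its aryl amide instead of the two methyl groups of compound 1; the difference between the two cores is not broken down here. In this assay compound 2 gives 56.1%, level with compound 1 at the digits printed.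

Compound 4, `CCN1CCc2c(c(C(C)(C)C)nn2C(=O)Nc2cccc(C(F)(F)F)c2)C1`, is not yet measured. It is related to compound 2 as compound 3 is to compound 1: tert-butyl in place of methyl on an aromatic carbon, at the same place in the shared core. Because a number 15 percentage points higher from compound 1 to compound 3 (beyond the scatter) was seen for the identical change, a step of a number 11.9 percentage points higher from compound 2 to compound 4 (beyond the scatter) is expected from compound 2 to compound 4, only with some caution since it rests on one pair. Compound 4 is therefore estimated to give 68% in this assay, most likely between 55% and 80%.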

Compound 4, a percentage reported as inhibition, in the whole organism at one dose (the size of the read-out at that dose, not a potency): 61.4%
Estimate against measurement, compound 4: 6.6 percentage points above, within the range that was stated.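

In this assay, tert-butyl in place of methyl on an aromatic carbon gives a number 5.3 percentage points higher from compound 2 to compound 4 (within the scatter), so on this core the change cannot be told apart from the usual spread of repeated measurements. Set beside the earlier pair, the two steps do not differ measurably from each other: the same change on two cores in this assay, a number 15 percentage points higher (beyond the scatter) from compound 1 to compound 3 and a number 5.3 percentage points higher (within the scatter) from compound 2 to compound 4, 9.7 percentage points apart, within the scatter of two such steps. For the compounds shown here, this fits a single effect of the change on both cores, but it does not establish one: only the step on the core of compound 1 stands clear of the scatter, and two pairs are a narrow basis for a rule about how the change carries over.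

Still open, going by these compounds, is whether the change would behave the same way with an aryl amide carrying other groups, such as a chlorine or a methoxy group. Open too, on these data alone, is what ethyl, isopropyl or a longer chain would give in place of methyl or tert-butyl, and how these compounds would behave at other doses.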